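Chloro placement on the benzyl ring of the sulfonyl core

This account rests on a few compounds, and the source may have more. Where it says the series, first, only, none or still open, it means among the compounds named here.

Compound 2 `O=C1c2ccccc2N(Cc2ccccc2)S(=O)(=O)N1Cc1ccccc1` carries an unsubstituted benzyl group on the shared core. In a functional assay on HEL cells (Homo sapiens) (on this read-out lower numbers stand for higher toxicity in this test and higher numbers for lower toxicity in this test), compound 2 gives > 50000 nM, which is a limit of the assay and not a number (the limit of > 50000 nM in this assay, at which 1 of the 2 values shown sits). Its measured partner compound 1 `O=C1c2ccccc2N(Cc2ccccc2)S(=O)(=O)N1Cc1ccc(Cl)cc1` carries chloro on that ring, and in this assay compound 1 gives 20000 nM. Going by the values given here, the single measured step, an at least 2.5-fold higher number from compound 1 to compound 2 (0.39 log units; beyond the scatter), shows that removing chloro pushed the read-out beyond what the test resolves.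

Compound 3 `O=C1c2ccccc2N(Cc2ccccc2)S(=O)(=O)N1Cc1ccccc1Cl` applies the reverse kind of change to compound 2: chloro in place of hydrogen on an aromatic carbon, here ortho to a large group, so phenyl becomes 2-chlorophenyl. Only an at least 2.5-fold higher number from compound 1 to compound 2 (0.39 log units; beyond the scatter) bears on this, and it runs the other way; chloro in this different place on the ring is not covered by any measured pair. For compound 3 a modest step toward a lower number in this assay is therefore expected, an at least 2.0-fold lower number from compound 2 to compound 3 (0.30 log units; that floor lies within the scatter). Compound 2 sits at a limit, so the size of that step cannot be fixed. Compound 3 is estimated at 25000 nM in this assay, within 10000 nM to 60000 nM, with a fair chance that the assay again reports only a limit.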

Compound 3, minimum cytotoxic concentration: 200000 nM
The estimate for compound 3 lay 8.0-fold (0.90 log units) below the measured number; measured number outside the range, above it.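

Moving chloro within the benzyl group, from 4-chlorophenyl to 2-chlorophenyl, gives in this assay a 10-fold higher number from compound 1 to compound 3 (1.00 log units; beyond the scatter), so the place of chloro on this ring counts and not only its presence. The low number of compound 1 therefore cannot be read as a general effect of chloro on this ring, since compound 3 also carries chloro and does not share that number. The step from compound 2 to compound 3 cannot be read, because compound 2 sits at a limit of the assay and has no number to compare with: the limit of > 50000 nM in this assay, at which 1 of the 3 values shown sits.

From the compounds shown here alone, it remains open whether compound 3 truly differs from compound 2, and whether the contrast between compound 1 and compound 3 belongs to chloro or to the ring place alone. Going by these compounds, a methoxy group, an amine or a carboxylic acid on the same ring would test this, and the benzyl group on the other nitrogen of the shared core also stands unchanged in all three compounds, so its contribution to the read-out stays unknown.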